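A few compounds are considered here, and "the series" means these few. Any claim that something is new, unique, unknown or untested is made for them only; others in the source may bear on it.

Three compounds built on one shared core were tested in an assay on LX2 cells for inhibition of COL1A1 promoter (Homo sapiens), read by a luciferase reporter, with a stated time of 24 h, tested at 50 uM; a lower number here means a weaker effect, a higher number a stronger effect of the compound at the concentration tested. Compound 1 `Cc1ccc(-n2cc(C(=O)Nc3cc(F)cc(F)c3)c(=O)c3ccc(N(C)C)nc32)cc1OCCCCCCC[N+]1(C)CCCC1` gives 55.9%. Compound 2 `CN(C)c1ccc2c(=O)c(C(=O)Nc3cc(F)cc(F)c3)cn(-c3ccc(Cl)c(OCCCCCCC[N+]4(C)CCCC4)c3)c2n1` gives 76.1%. Compound 3 `Cc1ccc(-n2cc(C(=O)Nc3cc(F)cc(F)c3)c(=O)c3ccc(N(C)C)nc32)cc1OCCCCCCC[n+]1ccccc1` gives 22.2%, the lowest of the three, and its steps to both other compounds lie beyond the usual scatter.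

Compound 2 differs from compound 1 by chloro in place of methyl on an aromatic carbon. That single change gave a number 20.2 percentage points higher from compound 1 to compound 2 (beyond the scatter). The core of compound 3 differs from the core of compound 1 by a group of 6 heavy atoms (5 carbon, 1 nitrogen; one six-membered aromatic ring with 1 hetero atom) in place of a group of 6 heavy atoms (5 carbon, 1 nitrogen; one five-membered non-aromatic ring with 1 hetero atom), on a saturated chain carbon, seven bonds along the chain from an oxygen on an aromatic ring, and this change gave a number 33.7 percentage points lower from compound 1 to compound 3 (beyond the scatter).

Compound 4 `CN(C)c1ccc2c(=O)c(C(=O)Nc3cc(F)cc(F)c3)cn(-c3ccc(Cl)c(OCCCCCCC[n+]4ccccc4)c3)c2n1` has not yet been measured in this assay. It differs from compound 3 by chloro in place of methyl on an aromatic carbon. Among the compounds with values here, the surroundings of that place are described in the same words for both pairs, so this is the same change as the one made from compound 1 to compound 2, now carried out on the core of compound 3. The expected step from this change is a number 19.8 percentage points higher from compound 3 to compound 4 (beyond the scatter). That expectation rests on the step seen when the change was made on compound 1, namely a number 20.2 percentage points higher from compound 1 to compound 2 (beyond the scatter), added to the starting point of compound 3 at 22.2%. Within the data shown here, only one earlier example of the change exists here, so the width of the range is wide. For compound 4 the estimated value in this assay is 42%. The expected range for compound 4 runs from 26% to 58%.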

Compound 4, a percentage reported as inhibition, at one concentration (the size of the read-out at that concentration, not a potency): 77.9%
The estimate for compound 4 lay 35.9 percentage points below the measured number; measured number outside the range, above it.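

Putting chloro in place of methyl on the aromatic carbon raised the read-out in this assay on both cores, but the size of the gain did not carry over, with a number 55.7 percentage points higher from compound 3 to compound 4 (beyond the scatter) set against a much smaller earlier step: the same change on two cores in this assay, a number 20.2 percentage points higher (beyond the scatter) from compound 1 to compound 2 and a number 55.7 percentage points higher (beyond the scatter) from compound 3 to compound 4, 35.5 percentage points apart, beyond the scatter of two such steps

The exchange on the chain, a six-membered aromatic ring in place of a five-membered non-aromatic ring, also behaved differently on the two cores, giving a number 1.8 percentage points higher from compound 2 to compound 4 (within the scatter) when chloro was present, so the effect of each change depends on the other and the two cannot simply be added: the same change on two cores in this assay, a number 33.7 percentage points lower (beyond the scatter) from compound 1 to compound 3 and a number 1.8 percentage points higher (within the scatter) from compound 2 to compound 4, 35.5 percentage points apart, beyond the scatter of two such steps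

Within the data shown here, this shows only that a step measured on one core was a poor guide to the same step on another in these four compounds; it does not show why the steps differ, how they would behave on a further core, or how the compounds would compare at any other concentration, since each number comes from a single concentration.

The compounds shown leave open whether bromo or fluoro on that aromatic carbon would follow the pattern seen with chloro. They also leave open how a shorter or longer chain, or a tertiary amine at the end of the chain, would change the picture.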